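Mirror-Flipped Centres in a Dimeric Bromo Compound

This account rests on a few compounds, and the source may have more. Where it says the series, first, only, none or still open, it means among the compounds named here.

In a functional assay on A549 cells (Homo sapiens) for cytotoxicity, read by sulforhodamine B assay (on this read-out lower numbers stand for higher toxicity in this test and higher numbers for lower toxicity in this test), compound 1 `O=C(NCCCCCNC(=O)C1=NO[C@]2(C=C(Br)C(=O)[C@@H](Br)[C@@H]2O)C1)C1=NO[C@]2(C=C(Br)C(=O)[C@@H](Br)[C@@H]2O)C1` gives 4100 nM. Within the data shown here, this is the lower of the two numbers measured so far, which makes it the more toxic of the pair. Compound 2 `COC1=C(Br)[C@H](O)[C@@]2(C=C1Br)CC(C(=O)NCCCCCNC(=O)C1=NO[C@]3(C=C(Br)C(=O)[C@H](Br)[C@@H]3O)C1)=NO2` gives 11200 nM, a gap beyond the usual scatter of repeated measurements.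

Compound 3 `O=C(NCCCCCNC(=O)C1=NO[C@]2(C=C(Br)C(=O)[C@H](Br)[C@@H]2O)C1)C1=NO[C@]2(C=C(Br)C(=O)[C@H](Br)[C@@H]2O)C1` is the next to be tested, and the change from compound 1 is subtle: the two compounds have the same atoms and bonds and differ only in configuration as drawn: 2 of 6 stereo elements differ; a stereocentre at a saturated ring carbon is drawn S in compound 1 and R in compound 3; a stereocentre at a saturated ring carbon is drawn S in compound 1 and R in compound 3. The two compounds have the same atoms and bonds and differ only in configuration as drawn, meaning the spatial arrangement at certain carbons. At two saturated ring carbons, a stereocentre drawn S in compound 1 is drawn R in compound 3.

Among the measured compounds shown here, no measured pair shows what such a change does on its own, so the expectation is loose. For the measured compounds named here, the span from compound 1 at 4100 nM to compound 2 at 11200 nM offers the only guide to how far related structures can move. The expected change is a 1.2-fold higher number from compound 1 to compound 3 (0.09 log units; within the scatter), with no step beyond the scatter anticipated, though a drift toward lower toxicity is possible. Compound 3 is estimated at 5000 nM, with an expected range from 1800 nM to 14000 nM.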

Compound 3, concentration lethal to 50% of the cells: 5500 nM
Estimate against measurement, compound 3: 1.1-fold (0.04 log units) below; low and high end bracket the measured number.
By their numbers in this assay, from the lowest: compounds 1 and 3 (each within the scatter of the next); then compound 2.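

Among these compounds, until now no two compounds differed in one place, so this is the first step that can be read. In this assay, redrawing two saturated ring carbons from S to R gives a 1.3-fold higher number from compound 1 to compound 3 (0.13 log units; within the scatter) and leaves compound 1 and compound 3 indistinguishable on this read-out, so at these two carbons the configuration as drawn shows no measurable effect on toxicity to these cells. This reading isolates configuration, and no other structural feature, as what was tested, because the pair offers nothing else to compare: the fact that compounds 1 and 3 differ only in the configuration as drawn.

On these data alone, the pair changes both carbons together, so it remains open whether changing only one of them would also leave the number within the scatter, or whether two separate effects happen to cancel here. It also leaves open whether this indifference to configuration would persist if a longer chain replaced the present one or if an amine or a carboxylic acid were added to the compound.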